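The compounds below may be only part of what the source reports. "The series", "measured", "known", "first", "only" and "open" are said of these compounds alone.

Four compounds share one core, a thiourea linking an indole-bearing ring to a second aromatic ring that carries a single varied group. Compound 1 `COc1ccc(NC(=S)Nc2ccc3[nH]ccc3c2)cc1` carries a methoxy and in an ADME assay on cells for inhibition of Amine oxidase [flavin-containing] A (Homo sapiens), read by spectrophotometry (a lower number here means a stronger inhibitor, a higher number a weaker inhibitor), compound 1 gives 36000 nM. Compound 2 `CC(=O)c1ccc(NC(=S)Nc2ccc3[nH]ccc3c2)cc1` carries an acetyl instead, and compound 2 gives 67000 nM. The step of a 1.9-fold higher number from compound 1 to compound 2 (0.27 log units; within the scatter) shows that swapping acetyl for methoxy made no difference worth noting. Compound 3 `O=C(c1ccccc1)c1ccc(NC(=S)Nc2ccc3[nH]ccc3c2)cc1` carries a benzoyl, and in this assay compound 3 is recorded as "not active" (no number reported), with no number reported. Compound 4 `CCOC(=O)c1ccc(NC(=S)Nc2ccc3[nH]ccc3c2)cc1` is built from compound 3 by the change (ethoxy in place of phenyl on a carbonyl carbon). Among the compounds with values here, no measured step matches this change directly; what is known is that all three measured neighbours are weak, with compound 1 and compound 2 sitting at high concentrations and compound 3 giving no number at all. Compound 4 is therefore expected to be weak as well, with an estimated value of 60000 nM and a plausible range from 20000 nM to 200000 nM.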

Compound 4, half-maximal inhibitory concentration: 71000 nM
Beside the measured number, compound 4's estimate is 1.2-fold (0.07 log units) below it; the range from low to high includes it.
By their numbers in this assay, from the lowest: compounds 1, 2 and 4 (each within the scatter of the next).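

In this assay, ethoxycarbonyl on the aromatic carbon gives a 1.1-fold higher number from compound 2 to compound 4 (0.03 log units; within the scatter) and a 2.0-fold higher number from compound 1 to compound 4 (0.29 log units; within the scatter) so methoxy, acetyl and ethoxycarbonyl cannot be told apart at this position. Compound 3 has no number and the step from its benzoyl to ethoxycarbonyl cannot be read, yet compound 4 shows that a carbonyl attached at this position does not by itself cost the assay a numerical reading, since ethoxy on that carbonyl carbon gives one where phenyl does not. Nothing measured here explains why these groups read alike or what sets benzoyl apart.

The compounds shown leave open whether an amine or a carboxylic acid at this position would give a number clearly apart from these. They also leave open how far compound 3 lies from the other three.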